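Propoxy for isopropoxy in the anilide sulfamide series

The source may hold more compounds than are shown below. What is called first, only, known or untested is meant among the compounds shown, and "the series" means these compounds.

Of the compounds shown here, two have been measured in an assay on HEK293 cells for inhibition of potassium channel subfamily T member 1 (Homo sapiens), read by thallium flux; on this read-out higher numbers stand for weaker inhibition and lower numbers for stronger inhibition. Compound 1 `CC1CCN(S(=O)(=O)N2CCN(CC(=O)Nc3cc(Cl)ccc3OC(C)C)CC2)CC1` gives 5100 nM in this assay. Compound 2 `COc1ccc(Cl)cc1NC(=O)[C@H](C)N1CCN(S(=O)(=O)N2CCC(C)CC2)CC1` gives 4400 nM in this assay, and the gap between compound 1 and compound 2 lies within the usual scatter of repeated measurements, so the two cannot be told apart on these numbers. Compound 3 `CCCOc1ccc(Cl)cc1NC(=O)CN1CCN(S(=O)(=O)N2CCC(C)CC2)CC1` has not yet been measured. Relative to compound 1 the change is propyl in place of isopropyl on an oxygen on an aromatic ring. Going by the values given here, no measured pair carries a change of this kind, so there is no step to lean on. Compound 3 is expected to stay close to compound 1, and a 1.0-fold lower number from compound 1 to compound 3 (0.01 log units; within the scatter) is estimated to be no step beyond the scatter in either direction. Compound 3 is estimated at 5000 nM in this assay, with a range from 2000 nM to 12000 nM.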

Compound 3, half-maximal inhibitory concentration: 4300 nM
For compound 3 the middle estimate is 1.2-fold (0.07 log units) above the measured one, and the stated range covers the measured number.
By their numbers in this assay, from the lowest: compounds 3, 2 and 1 (each within the scatter of the next).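

Propyl in place of isopropyl on an oxygen on an aromatic ring gives a 1.2-fold lower number from compound 1 to compound 3 (0.07 log units; within the scatter) in this assay and is the first step that can be read at this position. Rearranging these 3 carbons therefore moves the number no further than the scatter, so on this read-out the two chains cannot be told apart, although a single pair says nothing about other groups here. Nothing available bears on why the two chains read alike.

Still open, as far as these compounds go, is whether this position responds at all to a larger change, such as a longer chain like butyl, or an amine or a carboxylic acid carried at the end of the chain on that oxygen. A smaller group such as ethyl would show whether the flat reading extends to shorter chains.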